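Swapping Methyl for Chlorophenyl in an Insecticidal Series

This account rests on a few compounds, and the source may have more. Where it says the series, first, only, none or still open, it means among the compounds named here.

Compound 1 `CC(C)(C)n1ncc(OCc2nnc(-c3ccccc3Cl)o2)c(Cl)c1=O` gives 61200 nM in a functional assay on the whole organism for inhibition, with Mythimna separata as the target, with a stated time of 5 days; a higher number here means that more compound is needed for the effect, a lower number that less compound is needed. Compound 2 `CCn1ncc(OCc2nnc(-c3ccccc3)o2)c(Cl)c1=O` shows in this assay only the limit > 299000 nM. Compound 3 `Cc1nnc(COc2cnn(C(C)(C)C)c(=O)c2Cl)o1` likewise shows only the limit > 299000 nM.

Compound 3 therefore stands at a limit rather than at a number, sharing that position with compound 2, as summarized by the limit of > 299000 nM in this assay, at which 2 of the 3 values shown sit. Only compound 1 yields an actual number. Going by the values given here, the one measured step that touches compound 3 is an at least 4.8-fold higher number from compound 1 to compound 3 (0.68 log units; beyond the scatter), so trading the aryl group for methyl weakens the effect by at least that much. Compound 4 `CC(C)(C)n1ncc(OCc2nnc(-c3ccc(Cl)cc3)o2)c(Cl)c1=O` runs the other way: 4-chlorophenyl in place of methyl on an aromatic carbon. Because an at least 4.8-fold higher number from compound 1 to compound 3 (0.68 log units; beyond the scatter) was at least modest and upward, putting an aryl group back is expected to move the number downward by a comparable amount, though how a 4-chlorophenyl compares with the 2-chlorophenyl of compound 1 cannot be read from these compounds, and the value may again fall at a limit. Compound 4 is thus estimated at 80000 nM, within a range from 20000 nM to 299000 nM, the expected step being an at least 3.7-fold lower number from compound 3 to compound 4 (0.57 log units; beyond the scatter).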

Compound 4, half-maximal effective concentration: 1900 nM
Compound 4: middle estimate off by 42-fold (1.62 log units), on the high side; measured number outside the range, below it.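

Placing 4-chlorophenyl in place of methyl on this aromatic carbon gives an at least 150-fold lower number from compound 3 to compound 4 (2.19 log units; beyond the scatter) in this assay, a much larger change than the earlier step involving this position had revealed. The chlorophenyl groups are also not interchangeable, as 4-chlorophenyl in place of 2-chlorophenyl gives a 32-fold lower number from compound 1 to compound 4 (1.51 log units; beyond the scatter), so the form of the aryl group matters here, not only its presence. Compound 3 remains at a limit, so the first of these steps gives only a bound on the change, not its exact size: the limit of > 299000 nM in this assay, at which 2 of the 4 values shown sit.

The compounds shown leave open what a bromophenyl, a methoxyphenyl or a pyridine ring would do at this place. As far as these compounds go, whether the chlorine itself is needed also stays open, as compound 2 carries a plain phenyl but also differs in having an ethyl group.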